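This account rests on a few compounds, and the source may have more. Where it says the series, first, only, none or still open, it means among the compounds named here.

Compound 1 `COc1cc(OC)cc(C(=CC(C)=O)c2ccc(OC)c(OC)c2)c1`: > 10000 nM
Compound 2 `CCOc1cc(C(=CC#N)c2cc(OC)cc(OC)c2)ccc1OC`: 34 nM
Compound 3 `COc1cc(C(=CC#N)c2cc(OC)c(OC)c(OC)c2)cc(OC)c1OC`: > 10000 nM

Of the compounds shown here, three have been measured in a functional assay on HCT-116 cells (Homo sapiens) for cytotoxicity, read by scintillation counting and thymidine incorporation, with a stated time of 72 h; a higher number here means a weaker inhibitor, a lower number a stronger inhibitor. Compound 1 gives > 10000 nM, which is a limit of this assay and not a number. Compound 3 likewise gives > 10000 nM, again only a limit. Among the measured compounds shown here, compound 2 gives 34 nM, the single numerical value among the three. For the measured compounds named here, compound 1 therefore stands at the limit of > 10000 nM in this assay, at which 2 of the 3 values shown sit, and no measured step connects it to any other compound.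

Compound 4 `C=C(c1cc(OC)cc(OC)c1)c1ccc(OC)c(OC)c1` has not yet been measured. It differs from compound 1 by hydrogen in place of acetyl on a double-bonded chain carbon bound to a double-bonded chain carbon. Going by the values given here, no measured pair shows this change, so its size can only be guessed. A move toward a stronger inhibitor, that is a lower number, seems plausible because compound 2 gives 34 nM while carrying a nitrile rather than an acetyl on its chain, but the size is uncertain and could be nothing beyond the scatter. Compound 4 is expected to give 3000 nM, with a range from 300 nM to 20000 nM. The estimated step for compound 4 is thus an at least 3.3-fold lower number from compound 1 to compound 4 (0.52 log units; beyond the scatter).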

Compound 4, half-maximal inhibitory concentration: > 10000 nM
Compound 4 gave a limit, no number; the forecaster's own chance of this, stated with the estimate: 40%; middle value at least 3.3-fold (0.52 log units) away from the limit.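

In this assay compound 4 gives > 10000 nM, which is a limit and not a number. Among the compounds shown here, compound 1 gives > 10000 nM, also a limit, so no step between compound 1 and compound 4 can be read. The compounds shown leave open whether hydrogen in place of acetyl changes the inhibition at all.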